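Dropping one trifluoromethyl from compound 3

A few compounds are considered here, and "the series" means these few. Any claim that something is new, unique, unknown or untested is made for them only; others in the source may bear on it.

Compound 3 `COc1cc(Cl)cc(-c2nn(-c3cccc(NC(=O)Nc4cc(C(F)(F)F)cc(C(F)(F)F)c4)c3)cc2-c2ccncc2)c1` gives 23% in a functional assay on UACC-257 cells (Homo sapiens) for inhibition, read by sulforhodamine B assay, with a stated time of 48 h, tested at 1 uM (a lower number here means a stronger effect, a higher number a weaker effect of the compound at the concentration tested), the lowest of the three numbers measured. Compound 1 `O=C(Nc1cccc(-n2cc(-c3ccncc3)c(-c3cc(O)cc(Cl)c3)n2)c1)Nc1ccc(Cl)c(C(F)(F)F)c1` gives 58% and compound 2 `COc1cc(Cl)cc(-c2nn(-c3cccc(NC(=O)Nc4ccc(Cl)c(C(F)(F)F)c4)c3)cc2-c2ccncc2)c1` gives 83%. Among the measured compounds shown here, the only step between measured compounds that differ in one place, a number 25 percentage points higher from compound 1 to compound 2 (beyond the scatter), concerns methyl in place of hydrogen on an oxygen on an aromatic ring, and so it does not touch the part of the molecule changed here. Compound 4 `COc1cc(Cl)cc(-c2nn(-c3cccc(NC(=O)Nc4cccc(C(F)(F)F)c4)c3)cc2-c2ccncc2)c1` differs from compound 3 by hydrogen in place of trifluoromethyl on an aromatic carbon. For the measured compounds named here, no measured pair shares this change, so no step size can be taken over directly; compounds 2 and 3 carry different groups on that ring and their values lie far apart, which shows only that changes on this ring can move the read-out strongly in either direction. Compound 4 is therefore expected to move back toward the middle of the measured range, with a step of a number 27 percentage points higher from compound 3 to compound 4 (beyond the scatter). The estimate for compound 4 is 50%, with a range from 20% to 85%.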

Compound 4, a percentage reported as activity, at one concentration (the size of the read-out at that concentration, not a potency): 78%
The estimate for compound 4 lay 28 percentage points below the measured number; measured number inside the range.
By their numbers in this assay, from the lowest: compound 3; then compound 1; then compounds 4 and 2 (each within the scatter of the next).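

In this assay, among the compounds shown here, hydrogen in place of trifluoromethyl on this aromatic carbon gives the first direct reading of this position, and the step is large and toward a weaker effect (a number 55 percentage points higher from compound 3 to compound 4 (beyond the scatter)). Hydrogen in place of chloro on the same ring gives a step within the scatter (a number 5 percentage points lower from compound 2 to compound 4 (within the scatter)), so compound 2 and compound 4 cannot be told apart, and only compound 3, with its two trifluoromethyl groups, stands clear of them. Nothing available explains why this one group weighs so heavily on the read-out.

On these data alone, whether a nitrile or a tert-butyl group at this position would keep the stronger effect of compound 3 remains open. Also open, as far as these compounds go, is whether hydroxy in place of methoxy would give the same step on the ring of compound 3 as it does between compound 1 and compound 2.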